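Swapping trifluoromethyl for bromo on the aniline ring

The compounds below may be only part of what the source reports. "The series", "measured", "known", "first", "only" and "open" are said of these compounds alone.

Compound 3 `FC(F)(F)c1ccc(NCc2cn(-c3ccccc3)nc2-c2ccc(C(F)(F)F)cc2)cc1` is the starting point. In an ADME assay on BHK-21 cells (Mesocricetus auratus) for cytotoxicity, read by MTT assay, with a stated time of 72 h (on this read-out higher numbers stand for lower toxicity in this test and lower numbers for higher toxicity in this test), compound 3 gives 27000 nM, the lowest of the two numbers measured in this series. Within the data shown here, its nearest neighbour is compound 2 `Cc1ccc(NCc2cn(-c3ccccc3)nc2-c2ccc(C(F)(F)F)cc2)cc1`, which in this assay gives 88000 nM; the step of a 3.3-fold lower number from compound 2 to compound 3 (0.51 log units; beyond the scatter) is the only measured step here. Compound 1 `Brc1ccc(NCc2cn(-c3ccccc3)nc2-c2ccccc2)cc1` has no number in this assay, only a limit, > 100000 nM, as noted in the limit of > 100000 nM in this assay, at which 1 of the 3 values shown sits.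

Compound 4 `FC(F)(F)c1ccc(-c2nn(-c3ccccc3)cc2CNc2ccc(Br)cc2)cc1` differs from compound 3 in one place: bromo in place of trifluoromethyl on an aromatic carbon. Among the measured compounds shown here, no measured step shows this exact exchange. For the measured compounds named here, the one measured step, from compound 2 to compound 3, concerns a trifluoromethyl entering on the other ring, so it bears only loosely here. Compound 1 carries bromo at this position and sits at the limit, though it also differs on the second ring. An increase beyond the scatter seems more likely than a decrease, so compound 4 is expected at a 2.0-fold higher number from compound 3 to compound 4 (0.31 log units; beyond the scatter). The estimate for compound 4 in this assay is 55000 nM, between 20000 nM and 150000 nM.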

Compound 4, half-maximal cytotoxic concentration: 28000 nM
The estimate for compound 4 lay 2.0-fold (0.29 log units) above the measured number; the measured number falls inside the stated range.
By their numbers in this assay, from the lowest: compounds 3 and 4 (each within the scatter of the next); then compound 2. At a limit, above all of these: compound 1.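

Putting bromo in place of trifluoromethyl at this position makes no clear difference in this assay, giving a 1.0-fold higher number from compound 3 to compound 4 (0.02 log units; within the scatter). Methyl reads differently from both groups: bromo in its place gives a 3.1-fold lower number from compound 2 to compound 4 (0.50 log units; beyond the scatter), a step much like a 3.3-fold lower number from compound 2 to compound 3 (0.51 log units; beyond the scatter), so in these compounds the two larger-numbered changes point the same way and no compound goes against this. Trifluoromethyl in place of hydrogen on an aromatic carbon gives an at least 3.5-fold lower number from compound 1 to compound 4 (0.55 log units; beyond the scatter), but this step starts from compound 1, whose entry is a limit and not a number: the limit of > 100000 nM in this assay, at which 1 of the 4 values shown sits.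

With only methyl, trifluoromethyl and bromo shown at this position, it remains open how an amine or a carboxylic acid there would read in this assay. From the compounds shown here alone, how far the number can move at this position therefore also remains unknown.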